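Methoxy in place of the diazepanylmethyl group

The compounds below may be only part of what the source reports. "The series", "measured", "known", "first", "only" and "open" are said of these compounds alone.

Measured so far:
compound 1 `Cc1ccc(NC(=O)c2ccc(CN3CCCN(C)CC3)cc2)cc1-n1cc(-c2cnc3ccnn3c2)cn1`: 5880 nM
compound 2 `Cc1ccc(NC(=O)c2cccc(C(F)(F)F)c2)cc1-n1cc(-c2cnc3cccnn23)cn1`: < 2 nM
compound 3 `Cc1ccc(NC(=O)c2ccc(C(F)(F)F)cc2)cc1-n1cc(-c2cnc3cccnn23)cn1`: 10500 nM

In a functional assay on K562 cells (Homo sapiens) for antiproliferative activity, read by CCK-8 assay, with a stated time of 24 h (on this read-out higher numbers stand for weaker inhibition and lower numbers for stronger inhibition), compound 1 gives 5880 nM, the lowest of the two plain numbers shown, with compound 3 nearest to it. Compound 3 gives 10500 nM, which lies within the scatter of compound 1. The value of compound 2 is a limit of this assay, not a number (the limit of < 2 nM in this assay, at which 1 of the 3 values shown sits). Within the data shown here, the only single-point step measured, an at least 5200-fold higher number from compound 2 to compound 3 (3.72 log units; beyond the scatter), concerns the position of the trifluoromethyl group on the benzamide ring and does not touch the part changed here. Compound 4 `COc1ccc(C(=O)Nc2ccc(C)c(-n3cc(-c4cnc5ccnn5c4)cn3)c2)cc1` differs from compound 1 by methoxy in place of (4-methyl-1,4-diazepan-1-yl)methyl on an aromatic carbon. Both groups sit at the same place on the benzamide ring, and that place is where compound 3 also carries its group; compound 1 and compound 3 are within the scatter of each other. Among the measured compounds shown here, no measured step follows this kind of exchange, so nothing points to a change beyond the scatter. Compound 4 is therefore expected to stay close to compound 1, with an estimated step of a 1.2-fold higher number from compound 1 to compound 4 (0.08 log units; within the scatter). The estimate for compound 4 in this assay is 7000 nM, with a range from 2000 nM to 25000 nM.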

Compound 4, half-maximal inhibitory concentration: 19700 nM
The estimate for compound 4 lay 2.8-fold (0.45 log units) below the measured number; the range from low to high includes it.
By their numbers in this assay, from the lowest: compounds 1, 3 and 4 (each within the scatter of the next, the first and the last beyond it). At a limit, below all of these: compound 2.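

In this assay, among these compounds, the exchange of (4-methyl-1,4-diazepan-1-yl)methyl for methoxy gives the first measured step at this aromatic carbon, para to a large group: a 3.4-fold higher number from compound 1 to compound 4 (0.53 log units; beyond the scatter) is seen. This position on the core of compound 1 therefore responds to the group it carries, though only modestly, and the smaller methoxy group with no ring does not lower the number. The larger group, with its seven-membered non-aromatic ring and two hetero atoms, gives the lower number of this single pair, but one pair sets no trend, and no measurement shown bears on why the number moves with this exchange.

The step changes the whole group at once, so the compounds shown do not separate the contribution of the seven-membered ring from that of its methylene link or of the ring nitrogens. Open too, from the compounds shown here alone, is how this position would respond on the same core to a simple dimethylaminomethyl group, a piperazinylmethyl group, a hydroxyl group or a carboxylic acid, any of which would help place the pair on a wider scale.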